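Series notes: remote substituent swap and acid dissociation

A few compounds are considered here, and "the series" means these few. Any claim that something is new, unique, unknown or untested is made for them only; others in the source may bear on it.

Measured so far:
compound 1 `CC(C)(C)c1ccc(-c2ccc3c(NCCCNCc4ccco4)ccnc3c2)cc1`: 9.47
compound 2 `c1coc(CNCCCNc2ccnc3cc(CC4CCCCC4)ccc23)c1`: 9.47

In a physicochemical assay for acid dissociation, compound 2 gives 9.47. For the measured compounds named here, its only measured neighbour is compound 1, and the single comparable step, no change at the digits printed from compound 1 to compound 2 (within the scatter), shows that exchanging one group at the substituted aromatic carbon of the shared core left the number unchanged. Compound 2 and compound 1 stand at the same figure.

Compound 3 `COc1ccc(Oc2ccc3c(NCCCNCc4ccco4)ccnc3c2)cc1` is not yet measured. It differs from compound 2 by 4-methoxyphenoxy in place of cyclohexylmethyl on an aromatic carbon. Going by the values given here, the one step that bears on this change, no change at the digits printed from compound 1 to compound 2 (within the scatter), was a swap at the same aromatic carbon and produced no step beyond the scatter in this assay. The expected step is therefore none beyond the scatter: a number 0.02 log units lower from compound 2 to compound 3 (within the scatter). Compound 3 is estimated to give 9.45 in this assay, with a range from 9.1 to 9.8. Among the compounds with values here, no measured compound carries an aryl ether at this position, so this rests on one step only.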

Compound 3, acid dissociation constant: 9.28
Estimate against measurement, compound 3: 0.17 log units above, within the range that was stated.
By their numbers in this assay, from the lowest: compounds 3, 1 and 2 (each within the scatter of the next).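

In this assay, an oxygen-linked group now joins the two carbon-linked groups at this aromatic carbon, and the outcome is the same: a number 0.19 log units lower from compound 2 to compound 3 (within the scatter) and a number 0.19 log units lower from compound 1 to compound 3 (within the scatter) both stay within the scatter. Across the three compounds shown, 4-(tert-butyl)phenyl, cyclohexylmethyl and 4-methoxyphenoxy cannot be told apart in this read-out, even though 4-methoxyphenoxy brings 2 hydrogen-bond acceptors and the group it replaces in compound 3 has 0. No evidence is available that bears on this result.

As far as these compounds go, whether an amine or a carboxylic acid at this aromatic carbon would give a step beyond the scatter remains open. Also open, from the compounds shown here alone, is whether a longer chain elsewhere on the molecule would move the number in this assay.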